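Aryl amide variation: nitro to fluoro step

The source may hold more compounds than are shown below. What is called first, only, known or untested is meant among the compounds shown, and "the series" means these compounds.

Three compounds sharing one core have been run through an ADME assay on MT4 cells (Homo sapiens) for cytotoxicity, read by MTT assay; on this read-out lower numbers stand for higher toxicity in this test and higher numbers for lower toxicity in this test. Compound 1 `O=C(CSc1nncnc1-c1ccccc1Cl)Nc1ccc(Cl)cc1Cl` gives 51000 nM; compound 2 `Cc1ccccc1NC(=O)CSc1nncnc1-c1ccccc1Cl` gives 142000 nM; compound 3 `O=C(CSc1nncnc1-c1ccccc1Cl)Nc1ccccc1[N+](=O)[O-]` gives 63000 nM. Compound 3 holds the second highest of the three numbers: its gap to compound 1 is within the scatter, so no order between them can be stated, while a 2.3-fold lower number from compound 2 to compound 3 (0.35 log units; beyond the scatter) places compound 2 clearly higher, on the less toxic side.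

The step under consideration leads to compound 4 `O=C(CSc1nncnc1-c1ccccc1Cl)Nc1ccccc1F`: fluoro in place of nitro on an aromatic carbon. Among the compounds with values here, no measured step involves fluoro, so the only direct precedent for changing the group on this aromatic carbon is the swap of methyl for nitro, where a 2.3-fold lower number from compound 2 to compound 3 (0.35 log units; beyond the scatter) was modest but beyond the scatter. Replacing the amide-type aryl wholesale gave a 2.8-fold higher number from compound 1 to compound 2 (0.44 log units; beyond the scatter) and a 1.2-fold higher number from compound 1 to compound 3 (0.09 log units; within the scatter), both small. Taken together these steps suggest that single-group changes at this position move this assay by at most a modest amount, with direction uncertain in the absence of any fluoro data. Compound 4 is therefore estimated at 90000 nM, within 45000 nM to 180000 nM, meaning an expected 1.4-fold higher number from compound 3 to compound 4 (0.15 log units; within the scatter) that may well stay within the scatter.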

Compound 4, half-maximal cytotoxic concentration: 98000 nM
Beside the measured number, compound 4's estimate is 1.1-fold (0.04 log units) below it, within the range that was stated.
By their numbers in this assay, from the lowest: compounds 1, 3, 4 and 2 (each within the scatter of the next, the first and the last beyond it).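

In this assay, fluoro in place of nitro on this aromatic carbon gives a 1.6-fold higher number from compound 3 to compound 4 (0.19 log units; within the scatter) and fluoro in place of methyl gives a 1.4-fold lower number from compound 2 to compound 4 (0.16 log units; within the scatter), so the 2-fluorophenyl compound cannot be separated from either neighbour, even though those two neighbours are themselves separated by a 2.3-fold lower number from compound 2 to compound 3 (0.35 log units; beyond the scatter) on the same carbon. Against the 2,4-dichlorophenyl amide, the 2-fluorophenyl group gives a 1.9-fold higher number from compound 1 to compound 4 (0.28 log units; within the scatter) and also stays within the scatter, whereas 2-methylphenyl gave a 2.8-fold higher number from compound 1 to compound 2 (0.44 log units; beyond the scatter) and lay beyond it. Fluoro therefore adds an intermediate point that shows no separation from any of the other three compounds, and no measurement shown here accounts for these numbers.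

From the compounds shown here alone, whether an amine, a carboxylic acid or a longer alkyl chain on this aromatic carbon would move the number beyond the scatter of compound 4 remains open. Also open, going by these compounds, is whether these small steps would hold with the 2-chlorophenyl group on the shared core replaced, since all four compounds carry that group unchanged.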